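Three compounds at the limit, a fourth awaits testing

The compounds below may be only part of what the source reports. "The series", "measured", "known", "first", "only" and "open" are said of these compounds alone.

Compound 1 `COc1cc(-c2ncnn2-c2ccccc2)cc(OC)c1OC` gives > 10000 nM in a functional assay on HeLa cells (Homo sapiens) for antiproliferative activity, read by MTT assay, with a stated time of 72 h (a lower number here means a stronger inhibitor, a higher number a weaker inhibitor), which is a limit of the assay.
Compound 2 `COc1cc(-c2ncnn2-c2ccc(Cl)cc2Cl)cc(OC)c1OC` gives > 10000 nM in this assay, again a limit.
Compound 3 `COc1cccc(-c2ncnn2-c2cc(OC)c(OC)c(OC)c2)c1` gives > 10000 nM in this assay, also a limit.

Compound 2 therefore stands at the limit of this assay, and it shares that position with every other measured compound (the limit of > 10000 nM in this assay, at which 3 of the 3 values shown sit). Among the compounds with values here, the only step between measured compounds that differ in one place, a step that the two limits leave unreadable from compound 1 to compound 2, cannot be sized, since both ends sit at a limit.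

Compound 4 `COc1cc(-c2ncnn2-c2ccc(Cl)cc2)cc(OC)c1OC` differs from compound 2 by hydrogen in place of chloro on an aromatic carbon. Within the data shown here, no measured step bears readably on this change: the step that the two limits leave unreadable from compound 1 to compound 2 is the closest relative, and it gives no direction or size. Hence no step beyond the scatter can be predicted in this assay from these numbers alone. With all three measured compounds at the limit (the limit of > 10000 nM in this assay, at which 3 of the 3 values shown sit), compound 4 is expected most likely to remain there too, so the estimated value for compound 4 is 12000 nM with a range from 3000 nM to 50000 nM. The step this estimate implies, a step that the limit leaves unreadable from compound 2 to compound 4, is expected to be none beyond the scatter.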

Compound 4, half-maximal inhibitory concentration: > 10000 nM
Compound 4 ended at the assay's limit; the forecaster's own chance of this, stated with the estimate: 80%; the middle value lies beyond the limit too.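

Compound 1, compound 2 and compound 4 all sit at a limit, so no step among them can be read: the limit of > 10000 nM in this assay, at which 4 of the 4 values shown sit.

The compounds shown leave open whether a chloro group changes the antiproliferative activity at all, and what change to the shared core would give a readable value in this assay.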